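Trisulfated disaccharide mimetic: expected binding to fibroblast growth factor 2

The source may report more compounds than this note shows. Statements on the series, on what has been measured and on what is new or still open speak of the compounds shown alone.

Measured so far:
compound 1 `CC(=O)N[C@H]1[C@@H](OC[C@@H](O)[C@@H](O)[C@H](O)[C@@H](O)CNc2cccc(NC(=O)CCCCC3CCSS3)c2)O[C@H](COS(=O)(=O)O)[C@H](OS(=O)(=O)O)[C@@H]1O[C@@H]1O[C@H](C(=O)O)[C@@H](O)[C@H](O)[C@H]1O` gives 16 nM
compound 2 `CC(=O)N[C@H]1[C@@H](OC[C@@H](O)[C@@H](O)[C@H](O)[C@@H](O)CNc2cccc(NC(=O)CCCCC3CCSS3)c2)O[C@H](COS(=O)(=O)O)[C@H](O)[C@@H]1O[C@@H]1O[C@H](C(=O)O)[C@@H](O)[C@H](OS(=O)(=O)O)[C@H]1O` gives 147 nM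

In an assay on isolated protein for binding affinity to fibroblast growth factor 2 (Homo sapiens), read by surface plasmon resonance (on this read-out higher numbers stand for weaker binding and lower numbers for tighter binding), compound 2 gives 147 nM, the highest of the two numbers; its nearest neighbour, compound 1, gives 16 nM, a gap beyond the scatter. Compound 3 `CC(=O)N[C@H]1[C@@H](OC[C@@H](O)[C@@H](O)[C@H](O)[C@@H](O)CNc2cccc(NC(=O)CCCCC3CCSS3)c2)O[C@H](COS(=O)(=O)O)[C@H](OS(=O)(=O)O)[C@@H]1O[C@@H]1O[C@H](C(=O)O)[C@@H](O)[C@H](OS(=O)(=O)O)[C@H]1O` is not yet measured. It differs from compound 2 by sulfo in place of hydrogen on an oxygen on a saturated carbon, so it carries the sulfooxy groups of both measured compounds. For the measured compounds named here, no measured step covers this change; it is expected to lower the number, roughly to the level of compound 1, as a 9.8-fold lower number from compound 2 to compound 3 (0.99 log units; beyond the scatter). For compound 3 the estimate is 15 nM, within 4 nM to 60 nM.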

Compound 3, dissociation constant: 60 nM
Estimate against measurement, compound 3: 4.0-fold (0.60 log units) below; the measured number falls inside the stated range.
By their numbers in this assay, from the lowest: compound 1; then compound 3; then compound 2.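

Sulfo in place of hydrogen on an oxygen on a saturated carbon does not act in one direction in this series: one such change gives a 2.5-fold lower number from compound 2 to compound 3 (0.39 log units; beyond the scatter), while another gives a 3.8-fold higher number from compound 1 to compound 3 (0.57 log units; beyond the scatter). Both steps are beyond the scatter, so in this assay the result depends on where the sulfooxy group is added, and adding more of these groups does not by itself give tighter binding.

No available evidence explains the opposite directions of these steps. On these data alone, whether a phosphate or an amine in place of either sulfooxy group would retain binding remains open.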